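Methoxy placed on the aryl ring of a methylated core

A few compounds are considered here, and "the series" means these few. Any claim that something is new, unique, unknown or untested is made for them only; others in the source may bear on it.

Compound 2 `Cn1nc(N)c2c(=O)[nH]c(-c3ccccc3)cc21` gives 9% in an assay on isolated protein for inhibition of ribosomal protein S6 kinase alpha-5 (Homo sapiens), read by mobility shift assay, tested at 30 uM; a lower number here means less inhibition, a higher number more inhibition at the concentration tested (going by the name of the read-out). Within the data shown here, it stands level with compound 3 `COc1ccc(-c2cc3c(c(N)nn3C)c(=O)[nH]2)cc1`, which gives 9%, the two together being the lowest of the three numbers known here; its furthest neighbour is compound 1 `COc1cccc(-c2cc3[nH]nc(N)c3c(=O)[nH]2)c1`, which gives 49%, a number higher by an amount beyond the scatter. Compound 1 differs from compound 2 in more than one place, so its value shows only what such a compound can reach.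

Compound 4 `COc1cccc(-c2cc3c(c(N)nn3C)c(=O)[nH]2)c1` carries methoxy in place of hydrogen on an aromatic carbon, on a six-membered aromatic ring of carbon only, meta to a large group. Among the measured compounds shown here, the one step of this kind that has been measured, no change at the digits printed from compound 2 to compound 3 (within the scatter), placed the same group elsewhere on the same ring and left the number unchanged within the scatter. For the measured compounds named here, that step is the only guide, and it argues for little movement; the higher number of compound 1 leaves open some upward room.

Compound 4 is therefore expected to give about 15%, between 3% and 35%, and the step of a number 6 percentage points higher from compound 2 to compound 4 (within the scatter) is expected to stay within or just beyond the scatter.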

Compound 4, a percentage reported as inhibition, at one concentration (the size of the read-out at that concentration, not a potency): 2%
For compound 4 the middle estimate is 13 percentage points above the measured one; measured number outside the range, below it.
By their numbers in this assay, from the lowest: compounds 4, 2 and 3 (each within the scatter of the next); then compound 1.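

With methoxy meta to a large group, the number in this assay stays within the scatter (a number 7 percentage points lower from compound 2 to compound 4 (within the scatter)), as it did for the placement on the same ring in the earlier step (no change at the digits printed from compound 2 to compound 3 (within the scatter)), so neither placement on the methylated core moves it. The large gap now has a single-place comparison: methyl in place of hydrogen on an aromatic nitrogen gives a number 47 percentage points lower from compound 1 to compound 4 (beyond the scatter) and thereby ties the higher number of compound 1 to that nitrogen's hydrogen rather than to the methoxy group. Nothing measured here gives a reason for this drop.

On these data alone, it remains open how other groups on that nitrogen, such as an ethyl group, would read. As far as these compounds go, it is also open whether an amine or a carboxylic acid on the aryl ring would raise the number on the core of compound 1.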